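The source may hold more compounds than are shown below. What is called first, only, known or untested is meant among the compounds shown, and "the series" means these compounds.

Measured in a functional assay on OVCAR-3 cells (Homo sapiens) for cytotoxicity; a higher number here means a weaker inhibitor of growth, a lower number a stronger inhibitor of growth:
Compound 1 `COc1ccccc1C#Cc1ccccc1C#CCCCCO`: 19800 nM
Compound 2 `OCCCCC#Cc1ccccc1C#Cc1cccs1`: 15000 nM
Compound 3 `COc1cccc(C#Cc2ccccc2C#CCCCCO)c1`: 10700 nM

Compound 2, at 15000 nM, lies within the scatter of both compound 1 and compound 3. Compound 4 `OCCCCC#Cc1ccccc1C#Cc1ccc(O)cc1` carries 4-hydroxyphenyl in place of thiophen-2-yl on a triple-bonded carbon. For the measured compounds named here, no step between measured compounds differing in one place is available, so the expectation rests only on the values of compound 2 at 15000 nM and compound 3 at 10700 nM, which show no separation. In this assay, no change beyond the scatter is expected, and the estimated step is a 1.4-fold lower number from compound 2 to compound 4 (0.13 log units; within the scatter). For compound 4 the estimated value is 11000 nM, with an expected range of 3500 nM to 30000 nM.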

Compound 4, concentration for 50% growth inhibition: 14800 nM
For compound 4 the middle estimate is 1.3-fold (0.13 log units) below the measured one; low and high end bracket the measured number.
By their numbers in this assay, from the lowest: compounds 3, 4, 2 and 1 (each within the scatter of the next).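

In this assay, for the compounds shown here, the exchange on this triple-bonded carbon gives a 1.0-fold lower number from compound 2 to compound 4 (0.01 log units; within the scatter) and so provides the only direct comparison here: 4-hydroxyphenyl and thiophen-2-yl cannot be told apart at this position. The read-out therefore stays within the scatter with a six-membered aromatic ring of carbon only in place of a five-membered aromatic ring with a hetero atom, and with a hydrogen-bond donor added. No measured evidence bears on why this is so. As far as these compounds go, it remains open whether an amine or a carboxylic acid on the phenyl ring, or a longer chain at the alcohol end, would move the number beyond the scatter.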